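Lipophilicity of a thioester and its ketone counterpart

This account rests on a few compounds, and the source may have more. Where it says the series, first, only, none or still open, it means among the compounds named here.

Measured compounds:
Compound 1 `CC#CCOC(=O)/C=C(C)/C=C/CC(C)CCCC(C)C`: 6.4
Compound 2 `CC(/C=C/CC(C)CCCC(C)C)=C\C(=O)O`: 5.95
Compound 3 `CC(/C=C/CC(C)CCCC(C)C)=C\C(=O)SC(C)C`: 8.39

In a physicochemical assay for lipophilicity (on this read-out lower numbers stand for lower lipophilicity and higher numbers for higher lipophilicity), compound 3 stands highest of the three, with compound 1 nearest at a number 1.99 log units higher from compound 1 to compound 3 (beyond the scatter) and compound 2 furthest at a number 2.44 log units higher from compound 2 to compound 3 (beyond the scatter). Compound 4 `CC(/C=C/CC(C)CCCC(C)C)=C\C(=O)CC(C)C` is not yet measured. It differs from compound 3 in one place (isobutyl in place of isopropylsulfanyl on a carbonyl carbon). For the measured compounds named here, the steps that bear on this change are those bringing isopropylsulfanyl onto the carbonyl carbon, a number 1.99 log units higher from compound 1 to compound 3 (beyond the scatter) and a number 2.44 log units higher from compound 2 to compound 3 (beyond the scatter), both large. Removing that group in favour of isobutyl is therefore expected to give a modest downward step in this assay, a number 0.89 log units lower from compound 3 to compound 4 (beyond the scatter). Compound 4 is estimated at 7.5, within the range 6.8 to 8.3.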

Compound 4, partition coefficient: 7.22
Compound 4: the middle estimate sits 0.28 log units above what was measured; measured number inside the range.
By their numbers in this assay, from the lowest: compound 2; then compound 1; then compound 4; then compound 3.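

In this assay, isobutyl on this carbonyl carbon gives a number 1.17 log units lower from compound 3 to compound 4 (beyond the scatter), so the value here depends on more than the carbon count of the incoming group and separates the isopropylsulfanyl and isobutyl pair. Isobutyl still gives a number 1.27 log units higher from compound 2 to compound 4 (beyond the scatter) and a number 0.82 log units higher from compound 1 to compound 4 (beyond the scatter), which places compound 4 above both the hydroxy and (but-2-yn-1-yl)oxy compounds. Nothing available explains the gap between isopropylsulfanyl and isobutyl.

Where an isopropylamino group on the same carbonyl carbon would fall remains open. So does whether a longer chain in place of isobutyl would raise the value further.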